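Swapping the hydroxylated ring on the sulfonyl sulfur

A few compounds are considered here, and "the series" means these few. Any claim that something is new, unique, unknown or untested is made for them only; others in the source may bear on it.

compound 1 `O=S(=O)(CCO)c1cccc(-c2ccc3nccc(-c4ccncc4)c3n2)c1` gives 55000 nM
compound 2 `O=S(=O)(c1cccc(-c2ccc3nccc(-c4ccncc4)c3n2)c1)N1CCC(O)CC1` gives 10000 nM
compound 3 `O=S(=O)(c1cccc(-c2ccc3nccc(-c4ccncc4)c3n2)c1)N1CC[C@H](O)C1` has no value yet

For the measured compounds named here, in a physicochemical assay for solubility, read by HPLC, using the shake flask method, measured as kinetic solubility, with a stated time of 20 h, at pH 6.5, tested at 200 uM (on this read-out higher numbers stand for higher solubility and lower numbers for lower solubility), compound 2 holds the lower of the two numbers so far, at 10000 nM while compound 1 gives 55000 nM on the same read-out. The move to compound 3 is 3-hydroxypyrrolidin-1-yl in place of 4-hydroxypiperidin-1-yl on a sulfonyl sulfur on a sulfonyl sulfur, and the entering group brings a defined stereocentre. Going by the values given here, only one measured step touches that sulfur, a 5.5-fold lower number from compound 1 to compound 2 (0.74 log units; beyond the scatter) and it replaced a different group, so it offers only a loose guide. Among the compounds with values here, no measured compound carries the five-membered ring. Both groups in the new change are hydroxylated non-aromatic rings, so a smaller step than that one is expected, slightly upward if anything, starting from compound 2 at 10000 nM as the anchor. What is expected is a 1.4-fold higher number from compound 2 to compound 3 (0.15 log units; within the scatter) and no move beyond the usual scatter is anticipated. In this assay the estimate for compound 3 is 14000 nM with 5000 nM to 40000 nM as the expected range.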

Compound 3, solubility: 20000 nM
Estimate against measurement, compound 3: 1.4-fold (0.15 log units) below, within the range that was stated.
By their numbers in this assay, from the lowest: compounds 2 and 3 (each within the scatter of the next); then compound 1.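

In this assay, the exchange of 4-hydroxypiperidin-1-yl for 3-hydroxypyrrolidin-1-yl on the sulfonyl sulfur comes out as a 2.0-fold higher number from compound 2 to compound 3 (0.30 log units; within the scatter), so this assay does not separate the six-membered from the five-membered hydroxylated ring, and the entry of a defined stereocentre brings no step beyond the scatter. The 2-hydroxyethyl group of compound 1 now stands apart from both rings rather than from one, since a 2.8-fold lower number from compound 1 to compound 3 (0.44 log units; beyond the scatter) sits alongside the earlier 5.5-fold lower number from compound 1 to compound 2 (0.74 log units; beyond the scatter), and neither ring compound goes against this within the three compounds shown. No measurement of any property is available to explain these numbers, and the account of this position therefore stays descriptive.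

The compounds shown leave open how the mirror-image 3-hydroxypyrrolidin-1-yl would read here, and whether the hydroxyl matters at all, which a plain pyrrolidin-1-yl or piperidin-1-yl ring would test. They also leave open where a ring with a second hetero atom, such as morpholin-4-yl or piperazin-1-yl, or a longer chain such as 3-hydroxypropyl, would fall on this read-out.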